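Methoxy for Methyl on the Benzyl Ether: Expected Toxicity

The source may hold more compounds than are shown below. What is called first, only, known or untested is meant among the compounds shown, and "the series" means these compounds.

Compound 1 `O=c1c(O)c(-c2ccccc2)oc2cc(OCc3ccccc3Cl)cc(O)c12` sits at the limit > 100000 nM in an ADME assay on Huh-5-2 cells (Homo sapiens) for cytotoxicity, read by WST assay, with a stated time of 3 days; on this read-out higher numbers stand for lower toxicity in this test and lower numbers for higher toxicity in this test. Compound 2 `N#Cc1ccccc1COc1cc(O)c2c(=O)c(O)c(-c3ccccc3)oc2c1` gives 22000 nM in this assay, while compound 3 `Cc1ccccc1COc1cc(O)c2c(=O)c(O)c(-c3ccccc3)oc2c1` gives 17000 nM, the lowest of the two numbers, though a 1.3-fold lower number from compound 2 to compound 3 (0.11 log units; within the scatter) stays within the scatter. From the chloro compound the move is larger: an at least 4.5-fold lower number from compound 1 to compound 2 (0.65 log units; beyond the scatter) and an at least 5.8-fold lower number from compound 1 to compound 3 (0.76 log units; beyond the scatter), both at least modest. Compound 4 `COc1ccccc1COc1cc(O)c2c(=O)c(O)c(-c3ccccc3)oc2c1` carries methoxy in place of methyl on an aromatic carbon. Among the measured compounds shown here, the steps that bear on this exchange at the same aromatic carbon, an at least 5.8-fold lower number from compound 1 to compound 3 (0.76 log units; beyond the scatter) and a 1.3-fold lower number from compound 2 to compound 3 (0.11 log units; within the scatter), span one modest and one negligible change, so in this assay no step beyond the scatter is expected in either direction. Compound 4 is therefore estimated at 20000 nM, between 8000 nM and 60000 nM, a step of a 1.2-fold higher number from compound 3 to compound 4 (0.07 log units; within the scatter).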

Compound 4, half-maximal cytotoxic concentration: > 100000 nM
Compound 4 gave a limit, no number; the forecaster's own chance of this, stated with the estimate: 15%; middle value at least 5.0-fold (0.69 log units) away from the limit.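

Methoxy on this aromatic carbon separates compound 4 from the lower pair in this assay, with an at least 5.8-fold higher number from compound 3 to compound 4 (0.76 log units; beyond the scatter) and an at least 4.5-fold higher number from compound 2 to compound 4 (0.65 log units; beyond the scatter). Chloro is thus no longer the only group here that reaches the limit, while methyl and nitrile stay within the scatter of each other. Compound 1 and compound 4 both stand at a limit, so the step between them cannot be read: the limit of > 100000 nM in this assay, at which 2 of the 4 values shown sit. From the compounds shown here alone, whether an amine or a longer ethoxy chain on this carbon would also reach that limit stays open.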